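Adding a chloro group to compound 1

The source may report more compounds than this note shows. Statements on the series, on what has been measured and on what is new or still open speak of the compounds shown alone.

In a functional assay on Jurkat cells (Homo sapiens) for inhibition, read by MTT assay, with a stated time of 72 h (a lower number here means a stronger inhibitor, a higher number a weaker inhibitor), compound 1 (`C=C(Br)C(=O)Nc1cccc(/C=C/C(=O)Nc2ccccc2)c1`) gives 5000 nM as the highest number of the three measured. Compound 2 (`C=C(Br)C(=O)Nc1cccc(/C=C/C(=O)Nc2cccc3ccccc23)c1`) gives 680 nM and compound 3 (`C=C(Br)C(=O)Nc1cccc(/C=C/C(=O)Nc2ccc(F)c(F)c2)c1`) gives 550 nM with these two values within the scatter of each other. Compound 4 (`C=C(Br)C(=O)Nc1cccc(/C=C/C(=O)Nc2ccc(Cl)cc2)c1`) is not yet measured and differs from compound 1 by chloro in place of hydrogen on an aromatic carbon with chloro in place of hydrogen on an aromatic carbon para to a large group. Within the data shown here, the one measured step that bears on this is a 9.1-fold lower number from compound 1 to compound 3 (0.96 log units; beyond the scatter) with 3,4-difluorophenyl in place of phenyl on an amide-type nitrogen. A step in the same direction but somewhat smaller is therefore expected. The expected change is a 4.2-fold lower number from compound 1 to compound 4 (0.62 log units; beyond the scatter) in this assay toward a lower number. Compound 4 is estimated at 1200 nM within a range of 450 nM to 3000 nM in this read-out.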

Compound 4, half-maximal inhibitory concentration: 2600 nM
Beside the measured number, compound 4's estimate is 2.2-fold (0.34 log units) below it; measured number inside the range.
By their numbers in this assay, from the lowest: compounds 3 and 2 (each within the scatter of the next); then compounds 4 and 1 (each within the scatter of the next).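

In this assay a lone chloro group on an aromatic carbon, para to a large group, gives a 1.9-fold lower number from compound 1 to compound 4 (0.28 log units; within the scatter), so this change does not move the number beyond the scatter. The 4-chlorophenyl group also falls short of the 3,4-difluorophenyl group, with a 4.7-fold higher number from compound 3 to compound 4 (0.67 log units; beyond the scatter), so the gain seen with that group does not extend to every halogen-bearing phenyl. No available evidence accounts for this difference.

Going by these compounds, whether a single fluoro, a methoxy or an amino group at this place would give a step beyond the scatter remains open. So does the effect of chloro at other places on the phenyl.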